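Series notes: cytotoxicity read-out and a methoxy-for-bromo step

The compounds below may be only part of what the source reports. "The series", "measured", "known", "first", "only" and "open" are said of these compounds alone.

Three compounds of the shared core carry numbers in an ADME assay on HEL cells (Homo sapiens) for cytotoxicity; on this read-out higher numbers stand for lower toxicity in this test and lower numbers for higher toxicity in this test. Compound 1 `O=C(COc1cccc2ccccc12)N/N=C/c1ccc(Br)cc1` gives 100 ug/mL in this assay, the largest figure of the three on paper, though the two other compounds fall within the scatter of it. Compound 2 `O=C(COc1cccc2ccccc12)N/N=C/c1cccc([N+](=O)[O-])c1` gives 61.2 ug/mL in this assay, and compound 3 `COc1cc(/C=N/NC(=O)COc2cccc3ccccc23)cc(OC)c1O` gives 52.8 ug/mL. Both gaps from compound 1 lie within the usual scatter, so the three are read as level: none of the groups on the six-membered aromatic ring of carbon only has so far moved this read-out beyond the scatter.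

Compound 4 `COc1ccc(/C=N/NC(=O)COc2cccc3ccccc23)cc1` has not been measured. It differs from compound 1 in one place: methoxy in place of bromo on an aromatic carbon.

Going by the values given here, no measured pair differs in one place, so no step size for a change of this kind is on hand. Since the three measured compounds, which vary only on that ring, sit within the scatter of one another, methoxy in place of bromo is expected to give no step beyond the scatter in this assay in either direction. Compound 4 is therefore expected at 80 ug/mL in this assay, within 40 ug/mL to 150 ug/mL. This expectation means an estimated step of a 1.3-fold lower number from compound 1 to compound 4 (0.10 log units; within the scatter).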

Compound 4, half-maximal cytotoxic concentration: 100 ug/mL
Estimate against measurement, compound 4: 1.3-fold (0.10 log units) below, and the stated range covers the measured number.
By their numbers in this assay, from the lowest: compounds 3, 2, 1 and 4 (each within the scatter of the next).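

In this assay, going by these compounds alone, methoxy in place of bromo on an aromatic carbon para to a large group gives no change at the digits printed from compound 1 to compound 4 (within the scatter), the first comparison between compounds that differ in one place. The level reading of the series therefore no longer rests only on compounds that differ in more than one place: for the change from 4-bromophenyl to 4-methoxyphenyl, a direct pair now shows no step beyond the scatter, even though the entering group brings one more heavy atom and one hydrogen-bond acceptor. No supporting measurement is available to explain why this pair reads level.

From the compounds shown here alone, it remains open whether an amine or a carboxylic acid on the same aromatic carbon, or a longer chain in place of methoxy, would also leave this read-out within the scatter. Going by these compounds, since the four compounds vary only on the six-membered aromatic ring of carbon only, it is also open whether the read-out would stay level with a change elsewhere in the shared core.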